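The source may report more compounds than this note shows. Statements on the series, on what has been measured and on what is new or still open speak of the compounds shown alone.

Measured so far:
compound 1, `O=C(CSc1nncnc1-c1cccc2ccccc12)Nc1ccc([N+](=O)[O-])cc1Cl` — 150000 nM
compound 2, `O=C(CSc1nncnc1-c1ccccc1Cl)Nc1ccc(Cl)cc1Cl` — 51000 nM

Both numbers come from an ADME assay on MT4 cells (Homo sapiens) for cytotoxicity, read by MTT assay; a higher number here means that more compound is tolerated, a lower number that less compound is tolerated. Compound 2 stands lowest of the two; compound 1 returns a higher number, and that gap lies beyond the usual scatter, so compound 2 is the less tolerated of the pair. For the measured compounds named here, no step between two measured compounds that differ in only one place is available, so nothing shows how a single change shifts the number.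

Compound 3, `O=C(CSc1nncnc1-c1ccccc1Cl)Nc1cccnc1Cl`, is not yet measured. It differs from compound 2 in one place: 2-chloropyridin-3-yl in place of 2,4-dichlorophenyl on an amide-type nitrogen. The two measured compounds give no guide to a change of this kind. In this assay the step from compound 2 to compound 3 is expected to be small, toward a higher number if anything, and it may well stay within the scatter. Compound 3 is estimated at 70000 nM, with a range from 30000 nM to 180000 nM. This estimate amounts to an expected step of a 1.4-fold higher number from compound 2 to compound 3 (0.14 log units; within the scatter).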

Compound 3, half-maximal cytotoxic concentration: 167000 nM
Beside the measured number, compound 3's estimate is 2.4-fold (0.38 log units) below it; the range from low to high includes it.
By their numbers in this assay, from the lowest: compound 2; then compounds 1 and 3 (each within the scatter of the next).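

In this assay, for the compounds shown here, this is the first single change read: 2-chloropyridin-3-yl in place of 2,4-dichlorophenyl on an amide-type nitrogen gives a 3.3-fold higher number from compound 2 to compound 3 (0.52 log units; beyond the scatter) and so moves the number beyond the scatter. The group at this position can therefore shift tolerance on its own, with the rest of compound 2 held constant. Nothing measured here explains the shift.

The step changes the ring nitrogen and the chlorine count together, so a single pair cannot show which of the two carries it. Also open, on these data alone, is how a plain phenyl or pyridin-3-yl without chlorine would read at this position, and whether an amine or a carboxylic acid on the same ring would move the number further.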